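The compounds below may be only part of what the source reports. "The series", "measured", "known", "first", "only" and "open" are said of these compounds alone.

Measured so far:
compound 1, `Cc1[nH]c(=O)n(C2CCCCC2)c1-c1ccccc1`: 47600 nM
compound 2, `Cc1[nH]c(=O)n(C)c1-c1ccc(OC(C)C)cc1`: 20400 nM

In a functional assay on brain (Rattus norvegicus, strain Wistar) for inhibition (a higher number here means a weaker inhibitor, a lower number a stronger inhibitor), compound 2 gives the lower of the two numbers; compound 1 gives the higher, a gap beyond the scatter. Compound 3 `CCCCCCCc1ccc(-c2c(C)[nH]c(=O)n2C)cc1` is not yet measured. It differs from compound 2 in one place: heptyl in place of isopropoxy on an aromatic carbon. Among the measured compounds shown here, no step between measured compounds matches this change. The step of a 1.7-fold lower number from compound 2 to compound 3 (0.23 log units; within the scatter) is expected to be a modest lowering of the number, possibly not beyond the scatter. For compound 3 in this assay the estimate is 12000 nM, with a range from 3000 nM to 50000 nM.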

Compound 3, half-maximal inhibitory concentration: 8400 nM
Estimate against measurement, compound 3: 1.4-fold (0.15 log units) above; the measured number falls inside the stated range.
By their numbers in this assay, from the lowest: compound 3; then compound 2; then compound 1.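

In this assay, the aromatic carbon para to a group of 8 heavy atoms responds to a change of substituent: heptyl in place of isopropoxy gives a 2.4-fold lower number from compound 2 to compound 3 (0.39 log units; beyond the scatter). The step is modest, but it shows that an all-carbon chain with no hydrogen-bond acceptor can replace isopropoxy here without the number rising. No available measurement gives a reason for this step.

From the compounds shown here alone, whether a longer chain such as decyl or a shorter one such as propyl would shift the number remains open, as does the effect of an amine or a carboxylic acid at this position. Compound 1 differs from compound 2 and compound 3 in more than one place, so it gives no reading on this position.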